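This account rests on a few compounds, and the source may have more. Where it says the series, first, only, none or still open, it means among the compounds named here.

Measured so far:
Compound 1, `O=C(c1ccc(F)cc1)N1CC(c2nc(-c3cccc(Cl)c3)no2)C1`, in an assay on HEK293 cells for positive allosteric modulation of metabotropic glutamate receptor 5 (Homo sapiens), read by FLIPR (on this read-out lower numbers stand for an effect already at smaller amounts and higher numbers for an effect only at larger amounts of compound), gives only a limit, > 10000 nM.
Compound 2, `Cc1cccc(-c2noc(C3CN(C(=O)C4CCC(C(F)(F)F)CC4)C3)n2)c1`, in this assay gives 1000 nM.

Compound 1 thus sits at the limit of > 10000 nM in this assay, at which 1 of the 2 values shown sits, so no number is known for it, only that any effect needs more compound than the assay covers. For the measured compounds named here, compound 2 differs from compound 1 in more than one place, so its value shows only that a numbered reading is reached.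

Compound 3, `O=C([C@@H]1CC2CCC1C2)N1CC(c2nc(-c3cccc(Cl)c3)no2)C1`, is not yet measured. It differs from compound 1 by a group of 7 heavy atoms (7 carbon; 2 five-membered non-aromatic rings of carbon only) in place of a group of 7 heavy atoms (6 carbon, 1 fluorine; one six-membered aromatic ring of carbon only), on a carbonyl carbon. Going by the values given here, no measured step between two compounds that differ in one place is available to guide the size of this change.

Compound 3 is expected to give 2500 nM, with a range from 500 nM to 10000 nM. This estimate means a step of an at least 4.0-fold lower number from compound 1 to compound 3 (0.60 log units; beyond the scatter), a gain beyond the scatter, although the limit at compound 1 leaves the true size uncertain.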

Compound 3, half-maximal effective concentration: 98 nM
The estimate for compound 3 lay 26-fold (1.41 log units) above the measured number; measured number below the stated range.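

In this assay replacing the 4-fluorophenyl on the carbonyl carbon with the group of two five-membered non-aromatic carbon rings gives an at least 100-fold lower number from compound 1 to compound 3 (2.00 log units; beyond the scatter) while the rest of the molecule stays the same. This single position can therefore decide whether a numbered reading is reached at all. The two groups have the same number of heavy atoms and no hydrogen-bond donors or acceptors, so these counts do not separate them, and compound 1 gives only a limit, which leaves the true size of the step unknown: the limit of > 10000 nM in this assay, at which 1 of the 3 values shown sits.

The compounds shown leave open whether the ring type or the defined stereocentre goes with the change. They also do not show how the opposite stereoisomer, a plain cyclohexyl or a tert-butyl would read on the same carbonyl carbon.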